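This account rests on a few compounds, and the source may have more. Where it says the series, first, only, none or still open, it means among the compounds named here.

In an ADME assay on MDCK cells (Canis lupus familiaris) for cytotoxicity, read by MTT assay, with a stated time of 24 h (a lower number here means that less compound is tolerated, a higher number that more compound is tolerated), compound 1 `N#CCCN(Cc1cccs1)S(=O)(=O)c1ccc(Br)cc1` gives > 173000 nM as a limit of the assay and not a number. Compound 2 `N#CCCN(Cc1ccco1)S(=O)(=O)c1ccc(Cl)cc1` gives > 205000 nM as a limit too, so its standing is known only as a limit, with no number behind it. Compound 3 `N#CCCN(Cc1ccco1)S(=O)(=O)c1ccc(Br)cc1` has not yet been measured. The structural change from compound 2 is bromo in place of chloro on an aromatic carbon in one place: bromo in place of chloro on an aromatic carbon, para to a large group. Within the data shown here, no step between measured compounds is available to size this change in this assay for this series. The expected step of an at least 1.1-fold lower number from compound 2 to compound 3 (0.05 log units; that floor lies within the scatter) is estimated to stay within the scatter, in neither direction beyond it. Compound 3 is estimated at 180000 nM with an expected range from 120000 nM to 260000 nM and is expected to be reported as a limit again.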

Compound 3, half-maximal cytotoxic concentration: > 180000 nM
Compound 3 gave a limit, no number (the forecaster's own chance of this, stated with the estimate: 85%); the middle value lies on the limit itself.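

Among these compounds, compound 1, compound 2 and compound 3 each stand only as a limit in this assay, so neither the step from compound 2 to compound 3 nor the one from compound 1 to compound 3 can be read. The compounds shown leave open where the half-maximal cytotoxic concentration of any of the three lies, and whether either change moves it.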